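Moving a Bromine: Expected Cytotoxicity of Compound 3

The compounds below may be only part of what the source reports. "The series", "measured", "known", "first", "only" and "open" are said of these compounds alone.

Compound 1 `COc1ccc(Nc2nnnn2-c2ccccc2Cl)cc1`: 100000 nM
Compound 2 `COc1ccc(-n2nnnc2Nc2ccccc2Br)cc1`: 137000 nM

Both were tested in an ADME assay on HaCaT cells (Homo sapiens) for cytotoxicity, read by MTT assay, with a stated time of 72 h; on this read-out higher numbers stand for weaker inhibition and lower numbers for stronger inhibition. Compound 2 gives 137000 nM, the highest of the two numbers; compound 1 gives 100000 nM, and the gap between them lies within the scatter of repeated measurements, so the two cannot be ranked. Compound 3 `COc1ccc(-n2nnnc2Nc2cccc(Br)c2)cc1` is not yet measured. It differs from compound 2 in one place: 3-bromophenyl in place of 2-bromophenyl on a nitrogen on an aromatic ring. Going by the values given here, no measured pair shows this change, so there is no step to lean on. Both measured compounds show weak inhibition in this assay. The step of a 1.1-fold lower number from compound 2 to compound 3 (0.06 log units; within the scatter) is expected to stay within the scatter, in no clear direction. Compound 3 is thus estimated at 120000 nM, within 50000 nM to 250000 nM.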

Compound 3, half-maximal inhibitory concentration: 138000 nM
For compound 3 the middle estimate is 1.2-fold (0.06 log units) below the measured one, and the stated range covers the measured number.
By their numbers in this assay, from the lowest: compounds 1, 2 and 3 (each within the scatter of the next).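

Going by these compounds alone, with a 1.0-fold higher number from compound 2 to compound 3 (0.00 log units; within the scatter) in this assay, this is the first measured pair to isolate a single change: 3-bromophenyl in place of 2-bromophenyl on a nitrogen on an aromatic ring. For these two compounds, moving the bromine leaves the number within the scatter, so the change cannot be said to alter cytotoxicity here. No supporting data bear on this result. Still open, from the compounds shown here alone, is whether an amine or a carboxylic acid in place of the bromine would give a clearly different number.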